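A few compounds are considered here, and "the series" means these few. Any claim that something is new, unique, unknown or untested is made for them only; others in the source may bear on it.

Measured compounds:
compound 1 `CCOC(=O)c1cnn(-c2nc(-c3ccccc3F)c(C#N)c(=O)n2C)c1N`, in a functional assay, with a stated time of 10 min; a lower number here means a stronger inhibitor, a higher number a weaker inhibitor: 86 ug/mL
compound 2 `CCOC(=O)c1cnn(-c2nc(-c3cccc(OC)c3OC)c(C#N)c(=O)n2C)c1N`, in this assay: 67 ug/mL
compound 3 `CCOC(=O)c1cnn(-c2nc(-c3ccco3)c(C#N)c(=O)n2C)c1N`, in this assay: 104 ug/mL

In this assay compound 3 is set apart from compound 1 by a 1.2-fold higher number from compound 1 to compound 3 (0.08 log units; within the scatter) and from compound 2 by a 1.6-fold higher number from compound 2 to compound 3 (0.19 log units; within the scatter); both steps lie within the scatter, as does a 1.3-fold lower number from compound 1 to compound 2 (0.11 log units; within the scatter), so on these numbers the three compounds cannot be told apart. Compound 4 `CCOC(=O)c1cnn(-c2nc(-c3ccc(Cl)cc3)c(C#N)c(=O)n2C)c1N` differs from compound 3 by 4-chlorophenyl in place of furan-2-yl on an aromatic carbon. All three measured steps exchange this same aromatic group for another, and none of them moves the number beyond the scatter, so a further exchange of the same kind is expected to behave alike. Compound 4 is therefore estimated at 85 ug/mL in this assay, with a range from 45 ug/mL to 160 ug/mL. The expected step is a 1.2-fold lower number from compound 3 to compound 4 (0.09 log units; within the scatter), which should stay within the scatter.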

Compound 4, half-maximal inhibitory concentration: 94 ug/mL
The estimate for compound 4 lay 1.1-fold (0.04 log units) below the measured number; measured number inside the range.
By their numbers in this assay, from the lowest: compounds 2, 1, 4 and 3 (each within the scatter of the next).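

With 4-chlorophenyl on this aromatic carbon, ortho to the cyano group, this assay still does not separate the compounds: the steps are a 1.1-fold lower number from compound 3 to compound 4 (0.04 log units; within the scatter), a 1.4-fold higher number from compound 2 to compound 4 (0.15 log units; within the scatter) and a 1.1-fold higher number from compound 1 to compound 4 (0.04 log units; within the scatter). A chlorine-bearing ring thus joins furan-2-yl and the two other phenyl groups without any step beyond the scatter. Nothing available offers a reason for this flat result.

On these data alone, whether an amine or a carboxylic acid at this position would move the number remains open. So does whether a longer alkyl chain in place of the aromatic ring would behave alike.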